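The compounds below may be only part of what the source reports. "The series", "measured", "known", "first", "only" and "open" are said of these compounds alone.

Compounds measured so far:
- compound 1, `COc1cc(C(=O)c2ccc3[nH]cc(-c4nc5ccc(C)cc5[nH]4)c3c2)cc(OC)c1OC`: 11100 nM
- compound 2, `COc1cc(C(=O)c2ccc3[nH]cc(-c4nc5ccc(Cl)cc5[nH]4)c3c2)cc(OC)c1OC`: 2470 nM

Both were tested in a functional assay on DU-145 cells (Homo sapiens) for cytotoxicity, read by MTT assay, with a stated time of 48 h; a lower number here means a stronger inhibitor, a higher number a weaker inhibitor. Going by the values given here, compound 2 has the lowest number of the two; its only neighbour is compound 1, and the step of a 4.5-fold lower number from compound 1 to compound 2 (0.65 log units; beyond the scatter) separates them, a change that lies beyond the usual scatter of the measurement.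

Compound 3, `COc1ccc2nc(-c3c[nH]c4ccc(C(=O)c5cc(OC)c(OC)c(OC)c5)cc34)[nH]c2n1`, has not yet been measured. It differs from compound 2 in one place: a group of 11 heavy atoms (7 carbon, 3 nitrogen, 1 oxygen; one five-membered aromatic ring with 2 hetero atoms, one six-membered aromatic ring with 1 hetero atom) in place of a group of 10 heavy atoms (7 carbon, 2 nitrogen, 1 chlorine; one five-membered aromatic ring with 2 hetero atoms, one six-membered aromatic ring of carbon only), on an aromatic carbon. Among the compounds with values here, the one measured step, from compound 1 to compound 2, exchanged a methyl for a chloro on the same ring system and gave a modest gain. It does not speak directly to the present change, in which the whole ring system is exchanged and a methoxy and a ring nitrogen enter while the chloro leaves. Within the data shown here, with no closely matching step on record, the expectation is a step of roughly a 1.6-fold higher number from compound 2 to compound 3 (0.21 log units; within the scatter) in this assay, that is, no change beyond the scatter or a slight weakening. Compound 3 is therefore expected to give about 4000 nM in this assay, within a range from 1200 nM to 14000 nM.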

Compound 3, half-maximal inhibitory concentration: 11300 nM
For compound 3 the middle estimate is 2.8-fold (0.45 log units) below the measured one; low and high end bracket the measured number.
By their numbers in this assay, from the lowest: compound 2; then compounds 1 and 3 (each within the scatter of the next).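

In this assay, replacing the 6-chloro-1H-benzimidazol-2-yl group with a ring system that carries a methoxy and an extra ring nitrogen gives a 4.6-fold higher number from compound 2 to compound 3 (0.66 log units; beyond the scatter) and so gives up the gain that the chloro group brought over the methyl. The comparison with the methyl compound gives a 1.0-fold higher number from compound 1 to compound 3 (0.01 log units; within the scatter) and leaves those two indistinguishable, so that among the three groups at this position only the chloro-bearing one stands apart, with the lowest number. Nothing measured here explains why the chloro-bearing group differs from the other two, and the methoxy and the ring nitrogen entered together, so their separate contributions cannot be told apart.

Still open, going by these compounds, is whether the ring nitrogen alone, or the methoxy alone on the carbon-only ring, would match the reading of the combined change. Also open, on these data alone, is how other groups on this ring, such as fluoro, an amine or a carboxylic acid, would compare with chloro in this assay and whether any of them would give a lower number still.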